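The compounds below may be only part of what the source reports. "The series", "measured", "known", "first", "only" and "open" are said of these compounds alone.

In a functional assay, read by spectrophotometry, with a stated time of 3 min (a lower number here means a stronger inhibitor, a higher number a weaker inhibitor), compound 1 `O=c1cc(/C=N\c2ccccc2O)c2c(OCc3ccccc3)cc(OCc3ccccc3)cc2o1` gives 7760 nM and compound 2 `Nc1ccccc1/N=C\c1cc(=O)oc2cc(OCc3ccccc3)cc(OCc3ccccc3)c12` gives 7530 nM while compound 3 `Nc1ccccc1/N=C\c1cc(=O)oc2cc(OCc3ccccc3)ccc12` gives 9250 nM so compound 1 stands in a close group, all three within the scatter of each other. Compound 4 `N/N=C\c1cc(=O)oc2cc(OCc3ccccc3)cc(OCc3ccccc3)c12` has amino in place of 2-hydroxyphenyl on a double-bonded nitrogen. Among the compounds with values here, two measured steps bear on this only indirectly. Amino in place of hydroxy gave a 1.0-fold lower number from compound 1 to compound 2 (0.01 log units; within the scatter) and hydrogen in place of benzyloxy gave a 1.2-fold higher number from compound 2 to compound 3 (0.09 log units; within the scatter) and neither removes the whole 2-hydroxyphenyl group. In this assay no step beyond the scatter is therefore expected, with low confidence and no favoured direction. The expected result is a 1.1-fold higher number from compound 1 to compound 4 (0.04 log units; within the scatter) and the uncertainty is wide. Compound 4 is estimated at 8500 nM (expected range 3000 nM to 25000 nM).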

Compound 4, half-maximal inhibitory concentration: 363000 nM
Beside the measured number, compound 4's estimate is 43-fold (1.63 log units) below it, outside the stated range (above it).
By their numbers in this assay, from the lowest: compounds 2, 1 and 3 (each within the scatter of the next); then compound 4.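

In this assay, what sits on the double-bonded nitrogen turns out to matter: amino in place of 2-hydroxyphenyl gives a 47-fold higher number from compound 1 to compound 4 (1.67 log units; beyond the scatter), and amino in place of 2-aminophenyl gives a 48-fold higher number from compound 2 to compound 4 (1.68 log units; beyond the scatter). The earlier steps all stayed within the scatter, so removing the whole aromatic ring is the only change shown to move the number beyond it. Nothing available explains this large weakening. The compounds shown leave open whether a plain phenyl, a methyl or a longer alkyl chain on that nitrogen would keep the number near that of compound 1, so how much of the ring is needed remains unknown.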